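The source may report more compounds than this note shows. Statements on the series, on what has been measured and on what is new or still open speak of the compounds shown alone.

Measured so far:
compound 1 `CC1=C(C(=O)OCC(C)C)C(c2cccs2)NC(=O)N1C` — 2%
compound 2 `CC1=C(C(=O)OCC(C)C)C(c2ccsc2)NC(=O)N1C` — 1%
compound 3 `CCC(CC)OC(=O)C1=C(C)NC(=O)NC1c1cccs1` — 6%

In an assay on membranes from HEK293 cells for displacement of a labelled ligand from adenosine receptor A2b (Homo sapiens), read by scintillation counting, with a stated time of 30 min, tested at 1 uM (a higher number here means more inhibition at the concentration tested (going by the name of the read-out), a lower number less inhibition), compound 1 gives 2% and compound 2 gives 1%. The change between them is thiophen-3-yl in place of thiophen-2-yl on a saturated ring carbon and its step is a number 1 percentage points lower from compound 1 to compound 2 (within the scatter). Compound 3 in this assay gives 6%; its core differs from the core of compound 1, and the difference between the two cores is not broken down here. All three values lie within the scatter of one another.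

Compound 4 `CCC(CC)OC(=O)C1=C(C)NC(=O)NC1c1ccsc1` has not yet been measured in this assay. It differs from compound 3 by thiophen-3-yl in place of thiophen-2-yl on a saturated ring carbon. This is the same kind of change as from compound 1 to compound 2, though the surroundings differ: in compound 3 the ring atom bears a group of 8 heavy atoms, whereas in compound 1 it bears an isobutoxycarbonyl group (7 heavy atoms). The step is expected to be a number 1 percentage points lower from compound 3 to compound 4 (within the scatter), resting on the earlier step of a number 1 percentage points lower from compound 1 to compound 2 (within the scatter) and on compound 3 giving 6%. Compound 4 is therefore estimated at 5%, with a range from 0% to 13%.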

Compound 4, a percentage reported as inhibition, at one concentration (the size of the read-out at that concentration, not a potency): 26%
The estimate for compound 4 lay 21 percentage points below the measured number; measured number outside the range, above it.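

In this assay, the swap of thiophen-2-yl for thiophen-3-yl on a saturated ring carbon did not carry over from one core to the other: the same change on two cores in this assay, a number 1 percentage points lower (within the scatter) from compound 1 to compound 2 and a number 20 percentage points higher (beyond the scatter) from compound 3 to compound 4, 21 percentage points apart, beyond the scatter of two such steps

The new pair shows a number 20 percentage points higher from compound 3 to compound 4 (beyond the scatter), so for these two pairs the outcome of the change depends on the core that carries it, and the step on one core could not be read across to the other. Going by these compounds alone, this does not show which difference between the two cores accounts for the gap, nor how the change would behave on a third core, since only two pairs stand behind the comparison.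

From the compounds shown here alone, compound 4 gives 26% at a single concentration, which is a size of read-out and not a potency, so its potency stays open. Also open, going by these compounds, is whether a phenyl or furan-3-yl group in place of the thiophene, or a carboxylic acid on the ring atom that bears the group of 8 heavy atoms, would keep this number.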